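The compounds below may be only part of what the source reports. "The series", "measured", "known", "first", "only" and "open" are said of these compounds alone.

Measured in a functional assay on HeLa cells (Homo sapiens) for cytotoxicity, read by neutral red uptake, with a stated time of 3 days; a higher number here means a weaker inhibitor, a lower number a stronger inhibitor:
- Compound 1 `Cc1c(F)c(N)c2c(=O)cc(-c3ccc(N)c(F)c3)oc2c1F`: > 100000 nM, a limit
- Compound 2 `CCc1c(F)c(N)c2c(=O)cc(-c3ccc(N)c(F)c3)oc2c1F`: > 100000 nM, a limit
- Compound 3 `Nc1ccc(-c2cc(=O)c3c(N)c(F)c(O)c(F)c3o2)cc1F`: > 100000 nM, a limit

Compound 3 has no numerical value, only a limit, and compounds 1 and 2 offer no number to place it against. Compound 4 `Nc1ccc(-c2cc(=O)c3c(N)c(F)c(N)c(F)c3o2)cc1F` differs from compound 3 at one place: amino in place of hydroxy on an aromatic carbon. This puts amino in place of hydroxy on an aromatic carbon, ortho to two fluoro groups.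

Three measured steps change the group standing at this place: a step that the two limits leave unreadable from compound 1 to compound 3, a step that the two limits leave unreadable from compound 2 to compound 3 and a step that the two limits leave unreadable from compound 1 to compound 2. None of them gives a size. No step beyond the scatter and no direction is expected in this assay, because of the limit of > 100000 nM in this assay, at which 3 of the 3 values shown sit, compound 3 among them.

The expected result is a number no higher from compound 3 to compound 4 (the limit leaves the size open), and a reported limit is the likeliest outcome. Compound 4 is estimated at 100000 nM, with an expected range of 30000 nM to 300000 nM.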

Compound 4, half-maximal inhibitory concentration: 19000 nM
The estimate for compound 4 lay 5.3-fold (0.72 log units) above the measured number; the measured number lies below the stated range.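

In this assay, among the compounds shown here, amino on this aromatic carbon, ortho to two fluoro groups, gives the first number that is not a limit, with an at least 5.2-fold lower number from compound 3 to compound 4 (0.72 log units; beyond the scatter) when it replaces hydroxy. Against the two chains the picture is the same, with an at least 5.2-fold lower number from compound 2 to compound 4 (0.72 log units; beyond the scatter) for ethyl and an at least 5.2-fold lower number from compound 1 to compound 4 (0.72 log units; beyond the scatter) for methyl. The steps among compound 1, compound 2 and compound 3 cannot be read, so only now does this place prove sensitive to the group on it, and each new step gives a minimum size rather than a true one: the limit of > 100000 nM in this assay, at which 3 of the 4 values shown sit.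

On these data alone, whether a methylamino or dimethylamino group or an acetamide at this place would keep the lower number stays open. Also open, as far as these compounds go, is whether amino would give a similar step with hydrogen in place of the two fluoro groups.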